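A Step Away from 4-Ethylphenyl: Compound 4 Awaits Measurement

This account rests on a few compounds, and the source may have more. Where it says the series, first, only, none or still open, it means among the compounds named here.

In a toxicity assay on PC-12 cells (Rattus norvegicus) for cytotoxicity, read by MTT assay (on this read-out lower numbers stand for stronger inhibition and higher numbers for weaker inhibition), compound 1 `CCc1ccc(-n2nc(-c3ccc(C(F)(F)F)cc3O)nc2-c2ccccc2O)cc1` gives 147000 nM. Compound 2 `CC(C)c1ccc(-n2nc(-c3ccc(C(F)(F)F)cc3O)nc2-c2ccccc2O)cc1` gives 144000 nM, and the two stand level, with a 1.0-fold lower number from compound 1 to compound 2 (0.01 log units; within the scatter). Compound 3 `Oc1cc(C(F)(F)F)ccc1-c1nc(-c2ccccc2O)n(-c2ccc(Br)cc2)n1` gives 66800 nM, so compound 1 shares the upper end of these numbers with compound 2 alone.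

Compound 4 `Oc1cc(C(F)(F)F)ccc1-c1nc(-c2ccccc2O)n(-c2cccc(C(F)(F)F)c2)n1` has not yet been measured. It departs from compound 1 at one place, with 3-(trifluoromethyl)phenyl in place of 4-ethylphenyl on an aromatic nitrogen. Within the data shown here, no measured compound carries the entering group, so the evidence is indirect. The nearest guide is the change of the ethyl group itself, where bromo in its place gave a 2.2-fold lower number from compound 1 to compound 3 (0.34 log units; beyond the scatter). The same replacement of isopropyl gave a 2.2-fold lower number from compound 2 to compound 3 (0.33 log units; beyond the scatter). Both steps are modest, while the step from ethyl to isopropyl stayed within the scatter. Going by compound 3 and its 66800 nM, a modest move toward a lower number is expected in this assay, of about that size or somewhat smaller, although a result within the scatter would be no surprise. The estimate amounts to an expected 1.7-fold lower number from compound 1 to compound 4 (0.24 log units; within the scatter). For compound 4 the estimated value is 85000 nM, with an expected range of 40000 nM to 170000 nM.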

Compound 4, half-maximal inhibitory concentration: 49700 nM
Estimate against measurement, compound 4: 1.7-fold (0.23 log units) above; measured number inside the range.
By their numbers in this assay, from the lowest: compounds 4 and 3 (each within the scatter of the next); then compounds 2 and 1 (each within the scatter of the next).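

Among these compounds, compound 4 is the first compound here whose nitrogen-bound phenyl ring carries its group as 3-(trifluoromethyl)phenyl, and this ring can take that change in this assay without any loss: the step is a 3.0-fold lower number from compound 1 to compound 4 (0.47 log units; beyond the scatter) and, from the other alkyl-bearing compound, a 2.9-fold lower number from compound 2 to compound 4 (0.46 log units; beyond the scatter). Set against 4-bromophenyl, however, the new group gives a 1.3-fold lower number from compound 3 to compound 4 (0.13 log units; within the scatter), so among these four compounds the numbers form two pairs, 4-ethylphenyl with 4-isopropylphenyl and 4-bromophenyl with 3-(trifluoromethyl)phenyl, and no compound shown goes against that split. No measurement offered here accounts for this split or for the size of the steps.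

Compound 4 changes both the group and its place on the phenyl ring relative to compound 1, and the compounds shown cannot separate those two changes. Also open, from the compounds shown here alone, is how the number would respond to an amine or a carboxylic acid on this phenyl ring, or to an alkyl chain longer than ethyl or isopropyl.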